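The compounds below may be only part of what the source reports. "The series", "measured", "known", "first", "only" and "open" are said of these compounds alone.

Measured in a functional assay on HepG2 cells (Homo sapiens) for antiproliferative activity, read by MTT assay, with a stated time of 72 h; on this read-out higher numbers stand for weaker inhibition and lower numbers for stronger inhibition:
- compound 1 `COc1cc2c(Nc3ccc(C#N)cc3)ncnc2cc1OCCCN1CCCCC1`: 20700 nM
- compound 2 `COc1cc2c(Nc3ccc(C#N)cc3)ncnc2cc1OCCCN1CCC(C)CC1`: 32100 nM
- compound 3 `COc1cc2c(Nc3ccc(C#N)cc3)ncnc2cc1OCCCN1CCc2ccccc2C1`: > 100000 nM, which is a limit of the assay and not a number

Going by the values given here, only two compounds have true numbers, and compound 1 is one of them. The other lies within the scatter of it, a 1.6-fold higher number from compound 1 to compound 2 (0.19 log units; within the scatter).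

Compound 4 `COc1cc2c(Nc3ccccc3C#N)ncnc2cc1OCCCN1CCCCC1` keeps the core and chain of compound 1, with the same atoms joined differently: 2-cyanophenyl in place of 4-cyanophenyl on a nitrogen on an aromatic ring. It carries 2-cyanophenyl in place of 4-cyanophenyl on a nitrogen on an aromatic ring.

Among the compounds with values here, no measured step touches this group, so the evidence is indirect. All the measured changes lie at the far end of the chain. A methyl group made little difference, a 1.6-fold higher number from compound 1 to compound 2 (0.19 log units; within the scatter), whereas 1,2,3,4-tetrahydroisoquinolin-2-yl gave larger steps, an at least 4.8-fold higher number from compound 1 to compound 3 (0.68 log units; beyond the scatter) and an at least 3.1-fold higher number from compound 2 to compound 3 (0.49 log units; beyond the scatter).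

Only a small step is therefore expected, its direction uncertain, with a slight lean towards a higher number. The estimated step is a 1.4-fold higher number from compound 1 to compound 4 (0.16 log units; within the scatter). For compound 4 the expected value is 30000 nM, with an estimated range from 10000 nM to 90000 nM.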

Compound 4, half-maximal inhibitory concentration: 14200 nM
Compound 4: the middle estimate sits 2.1-fold (0.32 log units) above what was measured; low and high end bracket the measured number.
By their numbers in this assay, from the lowest: compounds 4, 1 and 2 (each within the scatter of the next, the first and the last beyond it). At a limit, above all of these: compound 3.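

Going by these compounds alone, the change to 2-cyanophenyl in place of 4-cyanophenyl on a nitrogen on an aromatic ring is the first measured step at this position, as all earlier steps lay at the far end of the chain. In this assay it gives a 1.5-fold lower number from compound 1 to compound 4 (0.16 log units; within the scatter), so this position accepts the rearrangement of the nitrile without a change that can be told from the scatter, and on this read-out compound 1 and compound 4 cannot be separated. Nothing shown here explains this result.

The compounds shown leave open whether 3-cyanophenyl, or a phenyl ring carrying a carboxylic acid or an amine in place of the nitrile, would stay as close to compound 1. They also leave open whether 2-cyanophenyl would give the same picture when paired with 4-methylpiperidin-1-yl or 1,2,3,4-tetrahydroisoquinolin-2-yl at the end of the chain.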